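Swapping the ring on the urea nitrogen: compound 3 to compound 4

The compounds below may be only part of what the source reports. "The series", "measured", "known", "first", "only" and "open" are said of these compounds alone.

Measured so far:
compound 1, `O=C(Nc1ccnc(C(F)(F)F)c1)Nc1ccc(F)c(C(F)(F)F)c1`, < 7 uL/min
compound 2, `O=C(Nc1ccc(F)c(C(F)(F)F)c1)Nc1cnccn1`, 210 uL/min
compound 3, `Cc1cc(NC(=O)Nc2ccc(F)c(C(F)(F)F)c2)on1`, 73 uL/min

In an ADME assay on microsomes from liver (Homo sapiens) for metabolic stability, using NADPH, with a stated time of 60 min (on this read-out higher numbers stand for fast clearance and lower numbers for slow clearance), compound 1 gives only a limit of the assay, (the limit of < 7 uL/min in this assay, at which 1 of the 3 values shown sits), and not a number. Of the two numbers that exist, compound 3 holds the lower one; its nearest neighbour is compound 2, and the step of a 2.9-fold lower number from compound 2 to compound 3 (0.46 log units; beyond the scatter) lies beyond the scatter. Within the data shown here, that step exchanges one ring on the amide-type nitrogen for another, so it is the only measured change of the same kind as the one now considered.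

Compound 4, `O=C(Nc1ccncc1)Nc1ccc(F)c(C(F)(F)F)c1`, differs from compound 3 in one place: pyridin-4-yl in place of 3-methyl-1,2-oxazol-5-yl on an amide-type nitrogen. Compound 1 also carries a pyridin-4-yl on that nitrogen, with an added trifluoromethyl, and sits at a limit, so it offers no number to compare. Among the measured compounds shown here, the single relevant step shows that changing this ring can move this assay by a modest amount, but gives no direction for a pyridin-4-yl. The expected step is therefore small, a 1.2-fold lower number from compound 3 to compound 4 (0.09 log units; within the scatter), within the scatter. Compound 4 is estimated at 60 uL/min, with a range from 20 uL/min to 180 uL/min.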

Compound 4, intrinsic clearance in a liver preparation (reported as CLH), per the amount of preparation that the assay uses in the Homo sapiens assay: 12 uL/min
Compound 4: middle estimate off by 5.0-fold (0.70 log units), on the high side; measured number below the stated range.
By their numbers in the Homo sapiens assay, from the lowest: compound 4; then compound 3; then compound 2. At a limit, below all of these: compound 1.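

Among these compounds, in the Homo sapiens assay, this position proves more sensitive than the single earlier step could show: pyridin-4-yl in place of 3-methyl-1,2-oxazol-5-yl gives a 6.1-fold lower number from compound 3 to compound 4 (0.78 log units; beyond the scatter), and pyridin-4-yl in place of pyrazin-2-yl gives an 18-fold lower number from compound 2 to compound 4 (1.24 log units; beyond the scatter). In a physicochemical assay for solubility, read by nephelometry, measured as kinetic solubility, at pH 2 (a higher number here means a more soluble compound, a lower number a less soluble compound), compound 3 gives 12.5 ug/mL and compound 4 gives 6.3 ug/mL, so these two values lie within the scatter of each other, and this ring change shows a clear difference only in the Homo sapiens assay. Compound 1 gives only a limit and not a number: the limit of < 7 uL/min in the Homo sapiens assay, at which 1 of the 4 values shown sits. In the Homo sapiens assay, hydrogen in place of trifluoromethyl on an aromatic carbon gives an at least 1.7-fold higher number from compound 1 to compound 4 (0.23 log units; that floor lies within the scatter), a step known only as a floor.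

The compounds shown do not settle which feature of the pyridin-4-yl ring goes with the lower number, since the rings compared differ in size, in their hetero atoms and in their substituents all at once. Also open, on these data alone, is whether an amine or a carboxylic acid on that ring would keep the number in the Homo sapiens assay low, and what either group would do to the number in the physicochemical assay.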